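Thiazolyl sulfonamide in place of the sulfonylguanidine

The source may report more compounds than this note shows. Statements on the series, on what has been measured and on what is new or still open speak of the compounds shown alone.

Two compounds of this series have numbers. Compound 1 `O=C(Nc1ccccc1)Nc1ccc(S(=O)(=O)Nc2ccnc3cc(C(F)(F)F)ccc23)cc1` gives 25400 nM in a functional assay on HT-1080 cells (Homo sapiens) for antiproliferative activity, read by sulforhodamine B assay, with a stated time of 48 h; a lower number here means a stronger inhibitor, a higher number a weaker inhibitor. Compound 2 `N=C(N)NS(=O)(=O)c1ccc(N/C(S)=N\c2ccnc3cc(C(F)(F)F)ccc23)cc1` gives 24300 nM in this assay; the two values lie within the scatter of each other, and the two structures differ in more than one place, so nothing is read from that pair beyond what the two numbers show. Compound 3 `O=S(=O)(Nc1nccs1)c1ccc(N/C(S)=N\c2ccnc3cc(C(F)(F)F)ccc23)cc1` has not been measured in this assay. It differs from compound 2 by a group of 5 heavy atoms (3 carbon, 1 nitrogen, 1 sulfur; one five-membered aromatic ring with 2 hetero atoms) in place of a group of 3 heavy atoms (1 carbon, 2 nitrogen; no ring), on a sulfonamide nitrogen, on a sulfonamide nitrogen whose other neighbour is the sulfonyl sulfur. Within the data shown here, no single-point step between measured compounds is available to anchor this change, so no direction beyond the scatter is expected in this assay. For compound 3 the expected step is a 1.1-fold lower number from compound 2 to compound 3 (0.04 log units; within the scatter). Compound 3 is therefore estimated at 22000 nM, with a range from 7000 nM to 65000 nM.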

Compound 3, half-maximal inhibitory concentration: 27300 nM
Beside the measured number, compound 3's estimate is 1.2-fold (0.09 log units) below it; the measured number falls inside the stated range.
By their numbers in this assay, from the lowest: compounds 2, 1 and 3 (each within the scatter of the next).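

Among these compounds, on the sulfonamide nitrogen whose other neighbour is the sulfonyl sulfur, replacing the open group of compound 2 with 1,3-thiazol-2-yl gives, in this assay, a 1.1-fold higher number from compound 2 to compound 3 (0.05 log units; within the scatter), the first single-place comparison. The position therefore takes a five-membered aromatic ring with 2 hetero atoms, and a group with 0 hydrogen-bond donors in place of one with 2, with no separation from the scatter in this assay. Nothing measured here bears on why these two numbers stand so close.

Still open, going by these compounds, is whether a methyl group, a plain phenyl ring or a pyridine ring on the same nitrogen would part from these numbers. A group carrying a carboxylic acid or an amine at this position is equally untested by the compounds shown.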